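The source may report more compounds than this note shows. Statements on the series, on what has been measured and on what is new or still open speak of the compounds shown alone.

Measured so far in an ADME assay on A549 cells (Homo sapiens) for cytotoxicity, read by resazurin assay, with a stated time of 48 h; on this read-out higher numbers stand for lower toxicity in this test and lower numbers for higher toxicity in this test:
Compound 1 `O=C(Nc1ccc(NCc2ccc(F)cc2)cc1Cl)c1cc(Cl)ccc1O` gives 54400 nM
Compound 2 `O=C(Nc1ccc(NCc2ccncc2)cc1Cl)c1cc(Cl)ccc1O` gives 65300 nM

Going by the values given here, compound 2 stands level with compound 1, the only other measured compound, within the scatter. Compound 3 `CC(C)(CCO)Nc1ccc(NC(=O)c2cc(Cl)ccc2O)c(Cl)c1` departs from compound 2 by 3-hydroxy-1,1-dimethylpropyl in place of (pyridin-4-yl)methyl on a nitrogen on an aromatic ring and so has no ring in the new group. Among the compounds with values here, the one measured step that bears on this is a 1.2-fold higher number from compound 1 to compound 2 (0.08 log units; within the scatter) and it exchanged one ring for another, so it is only a loose guide. No change beyond the scatter is therefore expected in this assay. The expected step is a 1.2-fold lower number from compound 2 to compound 3 (0.07 log units; within the scatter) and it stays within the scatter. For compound 3 the estimate is 55000 nM with an expected range from 25000 nM to 100000 nM as its ends.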

Compound 3, half-maximal cytotoxic concentration: 170000 nM
Estimate against measurement, compound 3: 3.1-fold (0.49 log units) below, and the stated range ends below it.
By their numbers in this assay, from the lowest: compounds 1 and 2 (each within the scatter of the next); then compound 3.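

In this assay, the substituent on a nitrogen on an aromatic ring proves able to shift the number beyond the scatter, which the exchange of one ring for another had not done. The open chain 3-hydroxy-1,1-dimethylpropyl, which has no ring, gives a higher number against both ring-bearing groups (a 2.6-fold higher number from compound 2 to compound 3 (0.42 log units; beyond the scatter); a 3.1-fold higher number from compound 1 to compound 3 (0.49 log units; beyond the scatter)). On these data alone, whether this follows from the loss of the ring, the hydroxy or the 1,1-dimethyl branching stays open, as does how a carboxylic acid or an amine in place of the hydroxy would read. Nothing available explains the rise.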